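Alkynyl series: cytotoxicity on Vero cells, toward compound 4

The source may hold more compounds than are shown below. What is called first, only, known or untested is meant among the compounds shown, and "the series" means these compounds.

Working notes on a small set of alkynyl analogues assessed in an ADME assay on Vero cells (Chlorocebus sabaeus) for cytotoxicity, read by MTT assay; on this read-out higher numbers stand for lower toxicity in this test and lower numbers for higher toxicity in this test. Compound 1 `CCCCCCC#Cc1cn([C@@H]2O[C@H](CO)[C@@H](O)[C@H]2O)c(=O)[nH]c1=O` gives 111000 nM. Compound 2 `O=c1[nH]cc(C#CC2CC2)c(=O)[nH]1` gives 252000 nM and compound 3 `O=c1[nH]cc(C#CC2CCCCC2)c(=O)[nH]1` gives 247000 nM; these two carry the bare core without the substituent present in compound 1, and their numbers lie within the scatter of each other, so no order between them is claimed. Compound 1 stands lowest of the three numbers, with compound 3 nearest and compound 2 furthest, both gaps beyond the scatter.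

Compound 4 `O=c1[nH]c(=O)n([C@@H]2O[C@H](CO)[C@@H](O)[C@H]2O)cc1C#CC1CC1` keeps the substituted core of compound 1 and differs from it in one place: cyclopropyl in place of hexyl on a triple-bonded carbon. Among the compounds with values here, no pair of measured compounds shows this change on the same core, so its size here is not known from the data. Between compound 2 and compound 3 the ring on the triple-bonded carbon changes without the numbers moving beyond the scatter, which suggests the group on the alkyne matters little when the core is bare. On that basis compound 4 is expected to sit near compound 1 or somewhat higher, with an expected step from compound 1 to compound 4 of a 1.4-fold higher number from compound 1 to compound 4 (0.16 log units; within the scatter), within the scatter. The estimate for compound 4 is 160000 nM, with a range from 70000 nM to 400000 nM.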

Compound 4, half-maximal cytotoxic concentration: 133000 nM
The estimate for compound 4 lay 1.2-fold (0.08 log units) above the measured number; low and high end bracket the measured number.
By their numbers in this assay, from the lowest: compounds 1, 4, 3 and 2 (each within the scatter of the next, the first and the last beyond it).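

On the shared core, cyclopropyl in place of hexyl on a triple-bonded carbon gives a 1.2-fold higher number from compound 1 to compound 4 (0.08 log units; within the scatter) in this assay and so leaves the two groups unseparated by this read-out. Within the data shown here, this is the first reading of a straight chain against a ring at this position, and of any change at this position on a core carrying the substituent of compound 1; the earlier pair, compound 2 and compound 3, compared only two rings on the bare core. The result therefore extends the flat picture at the triple-bonded carbon from ring against ring on the bare core to hexyl against cyclopropyl on the substituted core, although no evidence is available on what lies behind these readings.

Still open, as far as these compounds go, is whether the flat picture holds for a chain longer than hexyl, or for a group carrying an amine or a carboxylic acid, on the same triple-bonded carbon. Also open, from the compounds shown here alone, is whether hexyl on the bare core would read like the two rings there, which would show whether this change behaves the same on both cores.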